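Trading ethyl for trifluoromethyl on an aromatic carbon

This account rests on a few compounds, and the source may have more. Where it says the series, first, only, none or still open, it means among the compounds named here.

In a functional assay on aorta (Rattus norvegicus, strain Wistar), in the presence of a further agent that is not named here (on this read-out lower numbers stand for stronger inhibition and higher numbers for weaker inhibition), three compounds have been measured so far. Compound 1 `Cc1ccc2c(c1)N(C1=CCCC1=O)CC(C)(C)S2` gives 19500 nM, compound 3 `CCc1ccc2c(c1)N(C1=CCCC1=O)CC(C)(C)S2` gives 6460 nM, and compound 2 `CC1CN(C2=CCCC2=O)c2cc(C(F)(F)F)ccc2S1` gives 708 nM. Compound 3 therefore holds the second highest number of the three. The next compound to be measured is compound 4 `CC1(C)CN(C2=CCCC2=O)c2cc(C(F)(F)F)ccc2S1`, and the change is trifluoromethyl in place of ethyl on an aromatic carbon.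

For the measured compounds named here, only one measured step touches this place. It is a 3.0-fold lower number from compound 1 to compound 3 (0.48 log units; beyond the scatter), a modest gain in which the group grows by one carbon. That step suggests the group here matters, but it says nothing directly about trifluoromethyl. The better clue is compound 2, which also carries trifluoromethyl and gives 708 nM, a number clearly lower than that of compound 3, which gives 6460 nM. However, compound 2 also differs elsewhere in the core, and no measurement separates the two differences.

A clear move towards stronger inhibition therefore seems likely, of roughly the size of that gap. The expected change is an 8.1-fold lower number from compound 3 to compound 4 (0.91 log units; beyond the scatter) in this assay. For compound 4 the estimated value is 800 nM, with an expected range from 250 nM to 3000 nM.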

Compound 4, half-maximal inhibitory concentration: 8.32 nM
Estimate against measurement, compound 4: 96-fold (1.98 log units) above; measured number outside the range, below it.
By their numbers in this assay, from the lowest: compound 4; then compound 2; then compound 3; then compound 1.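

In this assay, trading ethyl for trifluoromethyl on this aromatic carbon gives a 780-fold lower number from compound 3 to compound 4 (2.89 log units; beyond the scatter), a far larger shift than the one seen when methyl gave way to ethyl at the same place, a 3.0-fold lower number from compound 1 to compound 3 (0.48 log units; beyond the scatter). Going straight from methyl to trifluoromethyl gives a 2300-fold lower number from compound 1 to compound 4 (3.37 log units; beyond the scatter), so among the three groups seen here, the choice of group on this carbon moves the number by a very wide margin, and trifluoromethyl gives the strongest inhibition of the three. The earlier compounds shown here also hid a second large effect in the core: an added methyl on a saturated ring carbon gives an 85-fold lower number from compound 2 to compound 4 (1.93 log units; beyond the scatter), which means that compound 2, lacking that methyl, gave a poor picture of what trifluoromethyl can reach on the core of compound 4.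

Going by these compounds, only methyl, ethyl and trifluoromethyl appear on this aromatic carbon, so it remains open whether a chlorine atom, a nitrile or a longer chain such as propyl would match trifluoromethyl, or whether the added ring methyl would count for as much with those groups. Nothing measured here explains why these steps are so large.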